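The source may hold more compounds than are shown below. What is called first, only, known or untested is meant among the compounds shown, and "the series" means these compounds.

Compound 1 `Cc1ccc2nc(N3CCCc4ccc(F)cc4C3)cc(NCCN(C)C)c2c1`: 89000 nM
Compound 2 `Cc1ccc2nc(N3CCCc4ccc(F)cc4C3)cc(NC(=O)CN)c2c1`: > 100000 nM

Of the compounds shown here, two have so far been measured in an ADME assay on HEp-2 cells (Homo sapiens) for cytotoxicity, read by CCK-8 assay, with a stated time of 5 days; a lower number here means that less compound is tolerated, a higher number that more compound is tolerated. Compound 1 `Cc1ccc2nc(N3CCCc4ccc(F)cc4C3)cc(NCCN(C)C)c2c1` gives 89000 nM in this assay, a high number that means a large amount of compound is tolerated by the cells. Compound 2 `Cc1ccc2nc(N3CCCc4ccc(F)cc4C3)cc(NC(=O)CN)c2c1` reaches only a limit of the assay in this assay, reported as > 100000 nM, which is the limit of > 100000 nM in this assay, at which 1 of the 2 values shown sits. Among the compounds with values here, the single measured step, an at least 1.1-fold higher number from compound 1 to compound 2 (0.05 log units; that floor lies within the scatter), therefore cannot be called a real change: it lies within the usual scatter, and both compounds sit at or near the top of what the assay can report.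

Compound 3 `CC(=O)NCCNc1cc(N2CCCc3ccc(F)cc3C2)nc2ccc(C)cc12` has not been measured. It differs from compound 2 by 2-acetamidoethyl in place of (aminomethyl)carbonyl on a nitrogen on an aromatic ring. Within the data shown here, the only measured step that bears on it is an at least 1.1-fold higher number from compound 1 to compound 2 (0.05 log units; that floor lies within the scatter), which was too small to separate from scatter and in which a different group on the same nitrogen made no visible difference. The expected step is accordingly small, a number no higher from compound 2 to compound 3 (the limit leaves the size open), with no direction favoured beyond the scatter. Compound 3 is therefore estimated to give about 100000 nM in this assay, within a range from 50000 nM to 250000 nM, and may well again reach only the limit of the assay.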

Compound 3, half-maximal cytotoxic concentration: 66000 nM
The estimate for compound 3 lay 1.5-fold (0.18 log units) above the measured number; the range from low to high includes it.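

Moving from one end group to another on the chain at this nitrogen, acetamido in place of dimethylamino gives a 1.3-fold lower number from compound 1 to compound 3 (0.13 log units; within the scatter), so in this assay this change at the end of the chain makes no difference that can be told from repeat measurements. From the compounds shown here alone, the change of the whole group, 2-acetamidoethyl in place of (aminomethyl)carbonyl, gives an at least 1.5-fold lower number from compound 2 to compound 3 (0.18 log units; that floor lies within the scatter); this is only a floor, so the true size of the step stays unknown, and what is printed does not stand clear of the scatter. Compound 2 gives a limit of the assay and not a number: the limit of > 100000 nM in this assay, at which 1 of the 3 values shown sits.

The compounds shown leave open whether any group on this nitrogen can move the number clearly beyond the scatter, for instance a carboxylic acid at the end of the chain or a longer chain carrying an amine. They also leave open whether the tolerance seen here depends on this nitrogen substituent at all, since the shared core stays the same in every compound.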